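The source may report more compounds than this note shows. Statements on the series, on what has been measured and on what is new or still open speak of the compounds shown alone.

Measured so far in a functional assay on HEY cells (Homo sapiens) for cytotoxicity, read by MTT assay, with a stated time of 72 h; a higher number here means a weaker inhibitor, a lower number a stronger inhibitor:
compound 1 `COc1cccc(CNC(=O)c2nc(Br)c3cccnc3c2N[C@H]2CC[C@H](N)CC2)c1` gives 7000 nM;
compound 2 `N[C@H]1CC[C@H](Nc2c(C(=O)NCc3cccc(C(F)(F)F)c3)nc(Br)c3cccnc23)CC1` gives 12000 nM.

Compound 1 holds the lower of the two numbers, yet the step of a 1.7-fold higher number from compound 1 to compound 2 (0.23 log units; within the scatter) lies within the scatter, so the two compounds stand level. Compound 3 `N[C@H]1CC[C@H](Nc2c(C(=O)Nc3ccccc3)nc(Br)c3cccnc23)CC1` differs from compound 1 in one place: phenyl in place of 3-methoxybenzyl on an amide-type nitrogen. Going by the values given here, the only measured step exchanged one group on the 3-methoxybenzyl ring and stayed within the scatter; no measured step replaces 3-methoxybenzyl with phenyl, so the direction is open. The expected step of a 1.3-fold higher number from compound 1 to compound 3 (0.11 log units; within the scatter) is therefore small and uncertain. Compound 3 is estimated at 9000 nM, between 3000 nM and 30000 nM.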

Compound 3, half-maximal inhibitory concentration: 1000 nM
Compound 3: the middle estimate sits 9.0-fold (0.95 log units) above what was measured; measured number below the stated range.
By their numbers in this assay, from the lowest: compound 3; then compounds 1 and 2 (each within the scatter of the next).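

At the amide-type nitrogen in this assay, changing the substituent on the benzyl ring left the numbers level, but phenyl gives a 7.0-fold lower number from compound 1 to compound 3 (0.85 log units; beyond the scatter) and a 12-fold lower number from compound 2 to compound 3 (1.08 log units; beyond the scatter) on the same core. This position therefore responds strongly to replacing either substituted benzyl with phenyl. Nothing measured here explains the drop.

Phenyl removes the ring substituent and the carbon link to the nitrogen together, so it remains open which of these changes matters. Plain benzyl or 3-methoxyphenyl on this nitrogen would separate the two.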